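The source may report more compounds than this note shows. Statements on the series, on what has been measured and on what is new or still open speak of the compounds shown alone.

Three compounds of the series have numbers in a functional assay for inhibition, tested at 100 ug/mL; a lower number here means a weaker effect, a higher number a stronger effect of the compound at the concentration tested. Compound 1 `Cc1cc(O)c(C(C)C)cc1-c1cc(-c2ccccc2)c(C#N)c(=O)[nH]1` gives 41%. Compound 2 `Cc1cc(O)c(C(C)C)cc1-c1cc(-c2cccs2)c(C#N)c(=O)[nH]1` gives 68% in this assay. Compound 3 `COc1ccc(-c2cc(-c3cc(C(C)C)c(O)cc3C)[nH]c(=O)c2C#N)cc1` gives 54% in this assay and stands second highest of the three, with compound 1 nearest and compound 2 furthest. All measured steps are modest: a number 27 percentage points higher from compound 1 to compound 2 (beyond the scatter), a number 13 percentage points higher from compound 1 to compound 3 (beyond the scatter) and a number 14 percentage points lower from compound 2 to compound 3 (beyond the scatter).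

Compound 4 `COc1cc(-c2cc(-c3cc(C(C)C)c(O)cc3C)[nH]c(=O)c2C#N)ccc1O` differs from compound 3 in one place: 4-hydroxy-3-methoxyphenyl in place of 4-methoxyphenyl on an aromatic carbon. The change keeps a six-membered aromatic ring of carbon only on the aromatic carbon ortho to a cyano group and brings in one hydrogen-bond donor and a second hydrogen-bond acceptor. Going by the values given here, the only measured step that touches this ring is a number 13 percentage points higher from compound 1 to compound 3 (beyond the scatter), where an added oxygen substituent moved the number upward by a modest amount. Among the compounds with values here, no measured step introduces a hydroxy, so the direction of this change rests on that single step and stays uncertain. A modest rise, or a number within the scatter of compound 3, is expected in this assay. For compound 4 the estimate in this assay is 60%, with a range from 42% to 78%. This estimate means an expected step of a number 6 percentage points higher from compound 3 to compound 4 (within the scatter).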

Compound 4, a percentage reported as inhibition, at one concentration (the size of the read-out at that concentration, not a potency): 44%
Compound 4: the middle estimate sits 16 percentage points above what was measured, within the range that was stated.
By their numbers in this assay, from the lowest: compounds 1, 4 and 3 (each within the scatter of the next, the first and the last beyond it); then compound 2.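

In this assay, the swap to 4-hydroxy-3-methoxyphenyl on the aromatic carbon ortho to a cyano group gives a number 10 percentage points lower from compound 3 to compound 4 (within the scatter) and so cannot be told from 4-methoxyphenyl at this position. The step of a number 3 percentage points higher from compound 1 to compound 4 (within the scatter) also lies within the scatter, so this more heavily substituted ring cannot be told from phenyl either, although a number 13 percentage points higher from compound 1 to compound 3 (beyond the scatter) stands beyond it; the rise seen with a single methoxy therefore does not simply carry over when a second oxygen substituent is present. Thiophen-2-yl remains clearly apart from the new group, with a number 24 percentage points lower from compound 2 to compound 4 (beyond the scatter) beyond the scatter, which leaves it the only group shown that is separated from both phenyl and 4-hydroxy-3-methoxyphenyl at this position. No measurement at hand explains the behaviour of this change.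

The compounds shown do not separate the contribution of the hydroxy from that of the methoxy, which 4-hydroxyphenyl and 3-methoxyphenyl at this position could do. As far as these compounds go, it also stays open whether the level of thiophen-2-yl extends to furan-2-yl, or how a phenyl ring carrying an amine or a carboxylic acid would read in this assay on the same core.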